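Sulfonamide head group exchange in a thiourea series

The source may report more compounds than this note shows. Statements on the series, on what has been measured and on what is new or still open speak of the compounds shown alone.

Compound 1 `Cc1cc(NS(=O)(=O)c2ccc(N/C(S)=N\c3ccnc4cc(C(F)(F)F)ccc34)cc2)on1`: in a functional assay on HeLa cells (Homo sapiens) for antiproliferative activity, read by sulforhodamine B assay, with a stated time of 48 h (a higher number here means a weaker inhibitor, a lower number a stronger inhibitor), compound 1 gives 60200 nM.
Compound 2 `Cc1noc(NS(=O)(=O)c2ccc(N/C(S)=N\c3ccnc4cc(C(F)(F)F)ccc34)cc2)c1C`: in this assay compound 2 was recorded only as "not active" (no number reported), with no number.

Compound 2 therefore stands without a value: nothing can be set beside the figure for compound 1, which itself lies far toward the weak end of the scale. Compound 3 `Cc1cc(C)nc(NS(=O)(=O)c2ccc(N/C(S)=N\c3ccnc4cc(C(F)(F)F)ccc34)cc2)n1` has not yet been measured. It differs from compound 2 in one place: 4,6-dimethylpyrimidin-2-yl in place of 3,4-dimethyl-1,2-oxazol-5-yl on a sulfonamide nitrogen. Going by the values given here, no step between two measured compounds covers this change, and compounds 1 and 2 differ from each other in another way, so the size and direction of the step can only be guessed. Among the compounds with values here, because compound 2 was inactive and compound 1 sits at 60200 nM, the two measured members are both weak, and compound 3 is expected to be weak as well, of the same order as compound 1, with a real chance that again no number is returned. The estimate for compound 3 in this assay is 60000 nM, with an expected range from 15000 nM to 250000 nM.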

Compound 3, half-maximal inhibitory concentration: 33000 nM
Beside the measured number, compound 3's estimate is 1.8-fold (0.26 log units) above it, within the range that was stated.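

In this assay the exchange of 3-methyl-1,2-oxazol-5-yl for 4,6-dimethylpyrimidin-2-yl on the sulfonamide nitrogen reads as a 1.8-fold lower number from compound 1 to compound 3 (0.26 log units; within the scatter) so at this position a six-membered aromatic ring and a five-membered one are not told apart by this read-out. Going by these compounds alone, the second dimethyl-bearing head group gives a different record: compound 2, with 3,4-dimethyl-1,2-oxazol-5-yl, is recorded as not active, while compound 3 gives 33000 nM and returns a number, but the step between these two cannot be read, and the record shows only that one has a value and the other has none. No accompanying data bear on the reason for these readings.

As far as these compounds go, compound 1 and compound 3 both lie toward the weak end of the scale, so it remains open whether any group on this sulfonamide nitrogen can move the series away from that end, for example a pyridin-2-yl ring, an acetyl group or a plain hydrogen. Also open, from the compounds shown here alone, is whether the reading depends on the sulfonamide head group alone or on the thiourea link and the trifluoromethyl group of the shared core, which stay the same throughout these compounds.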